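The source may hold more compounds than are shown below. What is called first, only, known or untested is meant among the compounds shown, and "the series" means these compounds.

Going by the values given here, in a functional assay on LOX IMVI cells (Homo sapiens) for cytotoxicity (on this read-out lower numbers stand for stronger inhibition of growth and higher numbers for weaker inhibition of growth), compound 1 (`COc1cccc(C#Cc2ccccc2C#CCCCCO)c1`) gives 6300 nM, while compound 2 (`OCCCCC#Cc1ccccc1C#Cc1cccc(O)c1`) gives 16700 nM, the higher of the two numbers so far. Compound 3 (`OCCCCC#Cc1ccccc1C#Cc1cccc(C(F)(F)F)c1`) is not yet measured. It has trifluoromethyl in place of hydroxy on an aromatic carbon, meta to a large group (trifluoromethyl in place of hydroxy on an aromatic carbon). Among the compounds with values here, one measured step touches this position: a 2.7-fold higher number from compound 1 to compound 2 (0.42 log units; beyond the scatter), a modest step beyond the scatter, with the hydroxy compound giving the higher number. Within the data shown here, no measured compound carries trifluoromethyl, so this step offers only a loose guide. A modest move to a lower number in this assay is expected, similar in size to that step, with a return to the level of compound 2 still possible. The expected step is a 2.1-fold lower number from compound 2 to compound 3 (0.32 log units; beyond the scatter). The estimate for compound 3 is 8000 nM, with an expected range of 2800 nM to 19000 nM.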

Compound 3, concentration for 50% growth inhibition: 17500 nM
Beside the measured number, compound 3's estimate is 2.2-fold (0.34 log units) below it, within the range that was stated.
By their numbers in this assay, from the lowest: compound 1; then compounds 2 and 3 (each within the scatter of the next).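

In this assay, trifluoromethyl in place of hydroxy gives a 1.0-fold higher number from compound 2 to compound 3 (0.02 log units; within the scatter) and so leaves the number unchanged within the scatter, even though a group with one hydrogen-bond donor and one acceptor gives way to a group with neither. Trifluoromethyl in place of methoxy gives a 2.8-fold higher number from compound 1 to compound 3 (0.44 log units; beyond the scatter) as a modest step beyond the scatter. Going by these compounds alone, compound 1, with methoxy, now stands apart from both compound 2 and compound 3, which the single earlier step could not show. No measurement is available to explain this result.

Still open, going by these compounds, is whether the lower number is specific to methoxy or would also appear with ethoxy, an amine or a nitrile on the same aromatic carbon. Also open, on these data alone, is whether these steps would hold with a longer chain in place of the chain ending in hydroxy.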